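Acyl variation at the carbonyl carbon of the shared core

The source may report more compounds than this note shows. Statements on the series, on what has been measured and on what is new or still open speak of the compounds shown alone.

Compound 1 `CC(=O)N(O)C(C)c1ccc(OCCc2ccccc2)cc1` gives 410 nM in an assay on RBL cells for inhibition of Polyunsaturated fatty acid 5-lipoxygenase (Rattus norvegicus); on this read-out lower numbers stand for stronger inhibition and higher numbers for weaker inhibition. Compound 2 `CC(=O)N(O)C(C)c1ccc2oc(-c3ccccc3)cc2c1` gives 490 nM; these two lie within the scatter of each other. Among the measured compounds shown here, compound 3 `COc1cccc(OC)c1C(=O)N(O)C(C)c1ccc2oc(-c3ccccc3)cc2c1` gives 3000 nM, the highest number of the three, and the one measured step at the carbonyl carbon, a 6.1-fold higher number from compound 2 to compound 3 (0.79 log units; beyond the scatter), is beyond the scatter. Compound 4 `CC(=O)OCC(=O)N(O)C(C)c1ccc2oc(-c3ccccc3)cc2c1` carries acetoxymethyl in place of 2,6-dimethoxyphenyl on a carbonyl carbon. For the measured compounds named here, no measured step covers acetoxymethyl itself; the only guide is that methyl on compound 2 gives a lower number than 2,6-dimethoxyphenyl on compound 3, and acetoxymethyl, with no ring, is the less aryl-like of the two options. A number between those of compound 2 and compound 3 is therefore expected, with wide uncertainty. Compound 4 is estimated at 1000 nM (range 300 nM to 4000 nM). The expected step is a 3.0-fold lower number from compound 3 to compound 4 (0.48 log units; beyond the scatter).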

Compound 4, half-maximal inhibitory concentration: 160 nM
Beside the measured number, compound 4's estimate is 6.3-fold (0.80 log units) above it, and the stated range ends above it.
By their numbers in this assay, from the lowest: compound 4; then compounds 1 and 2 (each within the scatter of the next); then compound 3.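

Acetoxymethyl on the carbonyl carbon reverses the direction seen so far at this position in this assay: the earlier step only rose, whereas here there is a 3.1-fold lower number from compound 2 to compound 4 (0.49 log units; beyond the scatter), so methyl is not the lowest-reading group at this place. Ring loss and the smaller group go with a 19-fold lower number from compound 3 to compound 4 (1.27 log units; beyond the scatter), though the two groups share the same hydrogen-bond acceptor count. No evidence on hand explains either step.

Open, as far as these compounds go, is whether acetoxy itself carries the step, or whether hydroxy, methoxy or an amine on that chain carbon would do the same. Also open, from the compounds shown here alone, is whether the step holds on the core of compound 1.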